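The compounds below may be only part of what the source reports. "The series", "measured", "known", "first", "only" and "open" are said of these compounds alone.

In a functional assay on HL-60 cells (Homo sapiens) for inhibition, read by MTT assay, with a stated time of 72 h (on this read-out higher numbers stand for weaker inhibition and lower numbers for stronger inhibition), three compounds have been measured so far:

- Compound 1 `Cc1nc(-c2ccccc2)c(C(=O)N2CCN(c3cccc(Cl)c3)CC2)o1` gives 39.2 nM
- Compound 2 `Cc1nc(-c2ccc(F)cc2)c(C(=O)N2CCN(c3cccc(Cl)c3)CC2)o1` gives 40.1 nM
- Compound 3 `COc1ccc(-c2nc(C)oc2C(=O)N2CCN(c3cccc(Cl)c3)CC2)cc1` is reported as "not active" (no number reported)

Only two of these results are numbers, and they cannot be told apart, so compound 2 stands level with compound 1. Compound 3 offers no number for comparison.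

Compound 4 `Cc1nc(-c2ccc(F)cc2)c(C(=O)N2CCN(c3ccc(Cl)cc3)CC2)o1` is built from the same atoms as compound 2, joined differently: 4-chlorophenyl in place of 3-chlorophenyl on an amine nitrogen in a ring. In words, this is 4-chlorophenyl in place of 3-chlorophenyl on an amine nitrogen in a ring.

Going by the values given here, the only measured step is a 1.0-fold higher number from compound 1 to compound 2 (0.01 log units; within the scatter). It swaps fluoro for hydrogen on an aromatic carbon, not the chlorophenyl group, so it bears only indirectly on this change. Among the compounds with values here, no measured compound carries the 4-chlorophenyl group, and the data favour no direction.

The expectation therefore starts from compound 2 at 40.1 nM, with no step beyond the scatter anticipated. The estimated step is a 1.4-fold higher number from compound 2 to compound 4 (0.14 log units; within the scatter). The range stays wide, as compound 3 at "not active" (no number reported) shows that this set can also lose a measurable number. For compound 4 the estimated value is 55 nM, and the expected range runs from 12 nM to 220 nM.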

Compound 4, half-maximal inhibitory concentration: "not active" (no number reported)
The entry for compound 4 holds no number, and the estimate cannot be compared.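

In this assay, going by these compounds alone, compound 2 gives 40.1 nM and compound 4 gives "not active" (no number reported) so no step between compound 2 and compound 4 can be read. Nothing shown here accounts for this result. The compounds shown leave open how large any difference between the 3-chlorophenyl and 4-chlorophenyl groups is on this shared core.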